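This account rests on a few compounds, and the source may have more. Where it says the series, first, only, none or still open, it means among the compounds named here.

Measured compounds:
- compound 1, `O=C(NCc1ccccc1)Nc1cccc(NC(=O)c2ccccn2)c1`, giving 2990 nM
- compound 2, `CN1CCN(C(=S)SCC(=O)Nc2cccc(NC(=O)c3ccccn3)c2)CC1`, giving 1340 nM

Both compounds were tested in a functional assay on A549 cells (Homo sapiens) for antiproliferative activity, read by MTT assay, with a stated time of 48 h; a higher number here means a weaker inhibitor, a lower number a stronger inhibitor. Compound 2 holds the lower of the two numbers; compound 1 sits at the higher one, and the gap between them is beyond the usual scatter, so compound 2 is the stronger inhibitor of this pair. Among the measured compounds shown here, the two compounds differ at more than one place, so no single step can be drawn from one to the other; only the two values themselves are known.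

Compound 3, `O=C(CSC(=S)N1CCN(c2ccccc2)CC1)Nc1cccc(NC(=O)c2ccccn2)c1`, has not been measured in this assay. It differs from compound 2 as follows: phenyl in place of methyl on an amine nitrogen in a ring. The change keeps the shared core and the side chain attached to it; only the group on the ring nitrogen of the non-aromatic ring is exchanged. For the measured compounds named here, no measured pair shows this particular exchange, so the size of the step is open. Going by the values given here, with no comparable step available, the expectation is a step from compound 2 to compound 3 of a 1.2-fold lower number from compound 2 to compound 3 (0.09 log units; within the scatter), close to the scatter and with no firm direction. The estimated value for compound 3 in this assay is 1100 nM, with a range from 400 nM to 3500 nM.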

Compound 3, half-maximal inhibitory concentration: 530 nM
The estimate for compound 3 lay 2.1-fold (0.32 log units) above the measured number; low and high end bracket the measured number.
By their numbers in this assay, from the lowest: compound 3; then compound 2; then compound 1.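

In this assay, the group on the ring nitrogen of the six-membered non-aromatic ring is now the one position in the series with a readable single-place step: phenyl in place of methyl gives a 2.5-fold lower number from compound 2 to compound 3 (0.40 log units; beyond the scatter). The position therefore affects the read-out, and it accepts phenyl, with its 6 heavy atoms and aromatic ring of carbon only, where methyl had 1 heavy atom, without the number rising; this step, labelled modest, moves it lower. Nothing measured here gives a reason for the step.

A single step cannot separate the presence of an aromatic ring from the larger size of the group on this nitrogen, and benzyl, cyclohexyl or pyridyl on the same nitrogen would be needed to tell these readings apart. Also open, going by these compounds, is whether a methoxy group or a chlorine atom on the phenyl ring would move the number further, and whether the same exchange would give a similar step with a different side chain on the shared core.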